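A Sulfonyl Chain Replaces 1-Amino-1-methylethyl

The source may hold more compounds than are shown below. What is called first, only, known or untested is meant among the compounds shown, and "the series" means these compounds.

Compound 1 `NCCOCCOc1ccc([C@H]2CC[C@]3(CC2)OOC2(O3)C3CC4CC(C3)CC2C4)cc1` and compound 2 `CC(C)(N)CCOc1ccc([C@H]2CC[C@]3(CC2)OOC2(O3)C3CC4CC(C3)CC2C4)cc1` carry the shared core and differ in one side chain. In an ADME assay on microsomes from liver (Homo sapiens) for metabolic stability, read by LC-MS, tested at 1 uM (on this read-out lower numbers stand for slow clearance and higher numbers for fast clearance), compound 1 gives < 7 mL.min-1.g-1 as its result, which is a limit of the assay. Compound 2 gives < 7 mL.min-1.g-1 as its result, again a limit and not a number. Among the compounds with values here, the only measured step is a step that the two limits leave unreadable from compound 1 to compound 2 and so offers no size to carry over. Compound 3 `NCCS(=O)(=O)CCOc1ccc([C@H]2CC[C@]3(CC2)OOC2(O3)C3CC4CC(C3)CC2C4)cc1` carries (2-aminoethyl)sulfonyl in place of 1-amino-1-methylethyl ((2-aminoethyl)sulfonyl in place of 1-amino-1-methylethyl on a saturated chain carbon, two bonds along the chain from an oxygen on an aromatic ring) on a saturated chain carbon, two bonds along the chain from an oxygen on an aromatic ring. The expected move is a step that the limit leaves unreadable from compound 2 to compound 3 and no shift beyond the scatter is expected in either direction. The estimate for compound 3 is 6 mL.min-1.g-1 with 3 mL.min-1.g-1 to 14 mL.min-1.g-1 as its expected range.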

Compound 3, intrinsic clearance in microsomes: 9 mL.min-1.g-1
The estimate for compound 3 lay 1.5-fold (0.18 log units) below the measured number, and the stated range covers the measured number.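

In this assay compound 3 gives 9 mL.min-1.g-1, the first result for this side chain position that is a number and not a limit. Placing (2-aminoethyl)sulfonyl in place of 1-amino-1-methylethyl gives an at least 1.2-fold higher number from compound 2 to compound 3 (0.10 log units; that floor lies within the scatter), and placing it in place of 2-aminoethoxy gives an at least 1.2-fold higher number from compound 1 to compound 3 (0.10 log units; that floor lies within the scatter). Both steps are only floors, and their true sizes stay unknown because each rests on a limit: the limit of < 7 mL.min-1.g-1 in this assay, at which 2 of the 3 values shown sit.

Open, as far as these compounds go, is where a side chain with a thioether in place of the sulfonyl, or with a longer carbon chain ending in the amine, would fall in this assay.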